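Oxan-4-yl for 3-hydroxypropyl on the aromatic nitrogen

The source may report more compounds than this note shows. Statements on the series, on what has been measured and on what is new or still open speak of the compounds shown alone.

Measured so far in an ADME assay for permeability, using PAMPA, with a stated time of 30 min, at pH 7.4; a lower number here means that the compound crosses the layer more slowly, a higher number that the compound crosses the layer faster:
Compound 1 `COc1ccc(-c2c(-c3ccc(OC)cc3)n(Cc3ccccc3)c3ncn(CCCO)c(=N)c23)cc1` gives > 1000 10^-6 cm/s, which is a limit of the assay rather than a number.
Compound 2 `COc1ccc(Cn2c(-c3ccccc3)c(-c3ccccc3)c3c(=N)n([C@H]4CC[C@H](O)CC4)cnc32)cc1` gives > 1000 10^-6 cm/s, likewise a limit.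
Compound 3 `N=c1c2c(-c3ccccc3)c(-c3ccccc3)n(Cc3ccccc3)c2ncn1CCCN1CCN(c2ccccc2)CC1` gives > 1000 10^-6 cm/s, likewise a limit.

Compound 1 therefore stands at the limit of this assay, and so do the two other compounds shown: the limit of > 1000 10^-6 cm/s in this assay, at which 3 of the 3 values shown sit. No pair of these compounds differs in one place, so no measured step in this assay is available.

Compound 4 `COc1ccc(-c2c(-c3ccc(OC)cc3)n(Cc3ccccc3)c3ncn(C4CCOCC4)c(=N)c23)cc1` is not yet measured. It differs from compound 1 as follows: oxan-4-yl in place of 3-hydroxypropyl on an aromatic nitrogen; in words, oxan-4-yl in place of 3-hydroxypropyl on an aromatic nitrogen. Since compound 1 sits at the limit, and every value shown sits there, no step beyond the scatter can be read from the numbers for this change. The expectation for compound 4 is that it also reaches the limit, with the estimated step from compound 1 to compound 4 in this assay being a step that the limit leaves unreadable from compound 1 to compound 4, that is, none beyond the scatter. For compound 4 the estimated value is 1200 10^-6 cm/s, with a range from 700 10^-6 cm/s to 2000 10^-6 cm/s.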

Compound 4, apparent permeability: > 1000 10^-6 cm/s
Compound 4 gave a limit, no number; the forecaster's own chance of this, stated with the estimate: 85%; the middle value lies beyond the limit too.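

Compound 1 and compound 4 both sit at a limit, so no step can be read for oxan-4-yl in place of 3-hydroxypropyl: the limit of > 1000 10^-6 cm/s in this assay, at which 4 of the 4 values shown sit.

The compounds shown leave open how far apart they lie in this assay and whether this change on the aromatic nitrogen shifts the read-out at all.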